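This account rests on a few compounds, and the source may have more. Where it says the series, first, only, none or still open, it means among the compounds named here.

Measured so far in a functional assay on SMMC-7721 cells (Homo sapiens) for cytotoxicity, read by MTT assay, with a stated time of 48 h (a lower number here means a stronger inhibitor, a higher number a weaker inhibitor), for this series:
Compound 1 `Cc1cc(Cl)cc2c(=O)cc(-c3ccccc3Cl)oc12`: "not determined" (no result reported)
Compound 2 `CCN(CC)Cc1cc(Cl)cc2c(=O)cc(-c3ccccc3Cl)oc12`: 810 nM
Compound 3 `O=c1cc(-c2ccccc2Cl)oc2c(CN3CCCCC3)cc(Cl)cc12`: 3400 nM

Only two of these compounds carry a number. Compound 3 at 3400 nM holds the higher of the two, and compound 2 at 810 nM holds the lower.

The next compound is compound 4 `CN(C)Cc1cc(Cl)cc2c(=O)cc(-c3ccccc3Cl)oc12`, which differs from compound 3 in one place: dimethylamino in place of piperidin-1-yl on a saturated chain carbon bound to an aromatic carbon. It therefore carries dimethylamino in place of piperidin-1-yl on a saturated chain carbon bound to an aromatic carbon.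

Among the measured compounds shown here, one measured step bears on this change. Going from diethylamino to piperidin-1-yl at the same place gave a 4.2-fold higher number from compound 2 to compound 3 (0.62 log units; beyond the scatter), which is modest but beyond the scatter. Compound 4 moves the opposite way, from the ring to an amine with no ring, though to dimethylamino and not diethylamino. For the measured compounds named here, no dimethylamino compound has been measured, so only part of that step is expected to return. A modest move to a lower number is therefore expected in this assay, and it may not clear the scatter. The estimated change is a 2.3-fold lower number from compound 3 to compound 4 (0.36 log units; beyond the scatter) in size. Compound 4 is estimated at 1500 nM with an expected range from 500 nM to 4500 nM in this assay.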

Compound 4, half-maximal inhibitory concentration: 1140 nM
Compound 4: middle estimate off by 1.3-fold (0.12 log units), on the high side, within the range that was stated.
By their numbers in this assay, from the lowest: compounds 2 and 4 (each within the scatter of the next); then compound 3.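

In this assay, the change from piperidin-1-yl to dimethylamino on a saturated chain carbon bound to an aromatic carbon gives a 3.0-fold lower number from compound 3 to compound 4 (0.47 log units; beyond the scatter), so the gap between the ring amine and the amines with no ring no longer rests on diethylamino alone. Between those two amines with no ring, the swap of diethylamino for dimethylamino gives a 1.4-fold higher number from compound 2 to compound 4 (0.15 log units; within the scatter), so methyl and ethyl groups on the nitrogen cannot be told apart here, and among the compounds with a number, compound 3, the one with the ring, stands apart from the other two. No measurement given here accounts for this difference between the ring and the open amines.

Among the compounds shown here, with only one ring amine in the set, the compounds leave open whether a smaller ring such as pyrrolidin-1-yl, or a ring holding an oxygen such as morpholin-4-yl, would fall with compound 3 or with compound 2 and compound 4. They also leave open whether a longer chain on the nitrogen, such as dipropylamino, would stay with the two open amines.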